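A nitro group added to the chloro compound

The source may report more compounds than this note shows. Statements on the series, on what has been measured and on what is new or still open speak of the compounds shown alone.

The shared core of this small set carries two phenyl rings. Compound 1 `O=C1NC(=O)/C(=C/c2cn(-c3ccccc3)nc2-c2ccccc2)S1` has both unsubstituted; compound 2 `O=C1NC(=O)/C(=C/c2cn(-c3ccccc3)nc2-c2ccc(Cl)cc2)S1` bears chloro in place of hydrogen on one of them. In a functional assay on the whole organism (strain Wistar albino) for inhibition, with Rattus norvegicus as the target, read by paw edema, in the formalin test, with stated times of 1 h and 3 h (a lower number here means that less compound is needed, a higher number that more compound is needed for the effect), compound 1 gives 21.3 mg/kg, and compound 2 gives 13 mg/kg. That is a 1.6-fold lower number from compound 1 to compound 2 (0.21 log units; within the scatter), so compound 2 stands at the lower of the two numbers, but its gap to compound 1 lies inside the usual scatter. Compound 3 `O=C1NC(=O)/C(=C/c2cn(-c3ccc([N+](=O)[O-])cc3)nc2-c2ccc(Cl)cc2)S1` differs from compound 2 by nitro in place of hydrogen on an aromatic carbon. For the measured compounds named here, no measured step touches this change: the only step seen so far, a 1.6-fold lower number from compound 1 to compound 2 (0.21 log units; within the scatter), alters the other ring and stayed within the scatter. With nothing pointing to a large move in either direction, the expected step is a 1.1-fold lower number from compound 2 to compound 3 (0.03 log units; within the scatter), not rising beyond the scatter. Compound 3 is therefore estimated at 12 mg/kg, with a likely range from 6 mg/kg to 25 mg/kg.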

Compound 3, dose for half-maximal effect: 15.2 mg/kg
Beside the measured number, compound 3's estimate is 1.3-fold (0.10 log units) below it, and the stated range covers the measured number.
By their numbers in this assay, from the lowest: compounds 2, 3 and 1 (each within the scatter of the next).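

For the compounds shown here, this is the first look at the ring that carries the nitro group: in this assay, going from phenyl to 4-nitrophenyl gives a 1.2-fold higher number from compound 2 to compound 3 (0.07 log units; within the scatter). A nitro group, with its three heavy atoms, can therefore be placed on this ring, para to a large group, and the number stays within the scatter of repeated measurements, so the two single changes seen so far, one on each ring, both remain within that scatter. Nothing measured here offers an explanation for this result.

From the compounds shown here alone, whether an amine or a carboxylic acid in this same place would shift the number beyond the scatter remains open. So does whether the nitro group would give a similarly small step on compound 1, which has no chloro.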